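From cyclopentyl to a larger group on the carbonyl carbon

A few compounds are considered here, and "the series" means these few. Any claim that something is new, unique, unknown or untested is made for them only; others in the source may bear on it.

In an ADME assay on HepG2 2.2.15 cells (Homo sapiens) for cytotoxicity (a higher number here means that more compound is tolerated, a lower number that less compound is tolerated), compound 1 `O=C(O)CCCC(=O)OCCc1c(-c2ccccc2Cl)c2cc(Cl)ccc2[nH]c1=O` gives 110000 nM and compound 2 `COCC(=O)OCCc1c(-c2ccccc2Cl)c2cc(Cl)ccc2[nH]c1=O` gives 74000 nM while compound 3 `O=C(OCCc1c(-c2ccccc2Cl)c2cc(Cl)ccc2[nH]c1=O)C1CCCC1` gives 46000 nM as the lowest of the three numbers. Going by the values given here, only one step between them (a 2.4-fold lower number from compound 1 to compound 3 (0.38 log units; beyond the scatter)) lies beyond the scatter. The other two (a 1.6-fold lower number from compound 2 to compound 3 (0.21 log units; within the scatter) and a 1.5-fold lower number from compound 1 to compound 2 (0.17 log units; within the scatter)) stay within it, so compound 3 is clearly set apart from compound 1 alone.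

Compound 4 `CC12CCC(C(=O)OCCc3c(-c4ccccc4Cl)c4cc(Cl)ccc4[nH]c3=O)(OC1=O)C2(C)C` keeps the shared core and alters the same end of the molecule, on the carbonyl carbon. The change from compound 3 is a group of 11 heavy atoms (9 carbon, 2 oxygen; one five-membered non-aromatic ring of carbon only, one five-membered non-aromatic ring with 1 hetero atom) in place of a group of 5 heavy atoms (5 carbon; one five-membered non-aromatic ring of carbon only), on a carbonyl carbon with no net charge on either group.

All three measured steps alter this end, and even the largest is modest. However, no measured compound carries a group this large, which leaves the estimate uncertain. The expected result is a 1.1-fold higher number from compound 3 to compound 4 (0.04 log units; within the scatter) and so no step beyond the scatter is expected. The estimate for compound 4 is 50000 nM with an expected range of 22000 nM to 110000 nM around it.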

Compound 4, half-maximal cytotoxic concentration: > 1800000 nM
Compound 4: no number, only a limit; the forecaster's own chance of this, stated with the estimate: 15%; middle value at least 36-fold (1.55 log units) from the limit.
By their numbers in this assay, from the lowest: compounds 3, 2 and 1 (each within the scatter of the next, the first and the last beyond it). At a limit, above all of these: compound 4.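

In this assay compound 4 gives no exact number, only a limit: the limit of > 1800000 nM in this assay, at which 1 of the 4 values shown sits.

Even read as a limit, the result gives an at least 39-fold higher number from compound 3 to compound 4 (1.59 log units; beyond the scatter), an at least 24-fold higher number from compound 2 to compound 4 (1.38 log units; beyond the scatter) and an at least 16-fold higher number from compound 1 to compound 4 (1.21 log units; beyond the scatter), all beyond the scatter, while the largest step among the earlier groups was a 2.4-fold lower number from compound 1 to compound 3 (0.38 log units; beyond the scatter). What is attached to this carbonyl carbon can therefore move the tolerated concentration much further than cyclopentyl, methoxymethyl and the 3-carboxypropyl group suggested.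

The compounds shown cannot say which feature of the entering group matters most: its 11 heavy atoms, its two rings or its 2 hydrogen-bond acceptors. They also leave open how a plain long carbon chain or an amine on this carbonyl carbon would compare.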